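The source may report more compounds than this note shows. Statements on the series, on what has been measured and on what is new or still open speak of the compounds shown alone.

Of the compounds shown here, three with a shared core have been tested in a functional assay on HeLa cells (Homo sapiens) for inhibition, read by MTT assay, with a stated time of 48 h; a higher number here means a weaker inhibitor, a lower number a stronger inhibitor. Compound 1 `COc1ccc(-c2nc3cc(/C=C4\SC(=O)NC4=O)ccc3[nH]2)cc1OC` gives 7830 nM. Compound 2 `COc1cc(-c2nc3cc(/C=C4\SC(=O)N(CC(=O)N5CCCCC5)C4=O)ccc3[nH]2)cc(OC)c1OC` gives 23300 nM, the highest of the three numbers, and compound 3 `COc1cc(OC)c(-c2nc3cc(/C=C4\SC(=O)N(CC(=O)N5CCCCC5)C4=O)ccc3[nH]2)cc1OC` gives 6890 nM. Compound 2 is thus the weakest inhibitor of the three; compound 1 lies nearest to it and compound 3 furthest, both with lower numbers beyond the scatter. Going by the values given here, the only measured step between compounds differing in one place, a 3.4-fold lower number from compound 2 to compound 3 (0.53 log units; beyond the scatter), concerns the pattern of methoxy groups on the trimethoxyphenyl group, not the group on the amide-type nitrogen in a ring. Compound 4 `COc1cc(-c2nc3cc(/C=C4\SC(=O)N(Cc5ccccc5)C4=O)ccc3[nH]2)cc(OC)c1OC` is compound 2 with phenyl in place of (piperidin-1-yl)carbonyl on a saturated chain carbon bound to an amide-type nitrogen in a ring. Among the compounds with values here, no measured step bears on this change: compound 1 and compound 2 differ in two places at once, so their values show only that the compound carrying the larger group at that nitrogen gave the higher number. With nothing to lean on, the expected step is a 1.6-fold lower number from compound 2 to compound 4 (0.19 log units; within the scatter), quite possibly none beyond the scatter. Compound 4 is therefore estimated at 15000 nM, within a range from 4000 nM to 50000 nM.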

Compound 4, half-maximal inhibitory concentration: 950 nM
Beside the measured number, compound 4's estimate is 16-fold (1.20 log units) above it; measured number outside the range, below it.
By their numbers in this assay, from the lowest: compound 4; then compounds 3 and 1 (each within the scatter of the next); then compound 2.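

The place on a saturated chain carbon bound to an amide-type nitrogen in a ring turns out to carry great weight in this assay and replacing (piperidin-1-yl)carbonyl with phenyl there gives a 25-fold lower number from compound 2 to compound 4 (1.39 log units; beyond the scatter) with the rest of the molecule unchanged. Going by these compounds alone, the earlier single-place step, a 3.4-fold lower number from compound 2 to compound 3 (0.53 log units; beyond the scatter), concerned only the pattern of methoxy groups, so this is the first direct reading of how far the number can move at this place. Nothing available explains this drop.

Going by these compounds, whether the gain comes from the phenyl ring itself or from the loss of the carbonyl and piperidine stays open, as does the effect of a longer chain before the phenyl or of an amine or carboxylic acid on it. On these data alone, it is also open whether benzyl gives a similar step on the methoxy pattern of compound 3.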